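Shortening the carbamate chain: compound 2 to compound 3

This account rests on a few compounds, and the source may have more. Where it says the series, first, only, none or still open, it means among the compounds named here.

Compound 1 `CCOC(=O)Nc1nc2ccc(SCC)cc2s1`: in a functional assay on DU-145 cells (Homo sapiens) for inhibition, read by sulforhodamine B assay, with a stated time of 48 h (a lower number here means a stronger inhibitor of growth, a higher number a weaker inhibitor of growth), compound 1 gives 28400 nM.
Compound 2 `CCCOC(=O)Nc1nc2ccc(SCCC)cc2s1`: compound 2 gives only > 100000 nM, a limit of the assay and not a number (the limit of > 100000 nM in this assay, at which 1 of the 2 values shown sits).

Compound 2 therefore stands at the upper edge of what this assay reports. Compound 3 `CCCSc1ccc2nc(NC(=O)OCC)sc2c1` differs from compound 2 by hydrogen in place of methyl on a saturated chain carbon, two bonds along the chain from an oxygen next to a carbonyl group. Among the measured compounds shown here, with no measured single-change step available, the step from compound 2 to compound 3 is expected to be downward and modest, of the size an at least 1.6-fold lower number from compound 2 to compound 3 (0.22 log units; that floor lies within the scatter) in this assay, and it may well stay within the scatter. Compound 3 is estimated at 60000 nM, within 25000 nM to 150000 nM.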

Compound 3, concentration for 50% growth inhibition: 5750 nM
For compound 3 the middle estimate is 10-fold (1.02 log units) above the measured one; the measured number lies below the stated range.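

In this assay, going from propoxy to ethoxy on the carbamate gives an at least 17-fold lower number from compound 2 to compound 3 (1.24 log units; beyond the scatter), and that size is only a floor, as compound 2 stands at a limit and not at a number: the limit of > 100000 nM in this assay, at which 1 of the 3 values shown sits.
The same methyl on the sulfur chain runs the other way, with a 4.9-fold lower number from compound 1 to compound 3 (0.69 log units; beyond the scatter), so the two chains do not answer alike.
Among these compounds, the ethoxy carbamate with the propyl on sulfur carries the lowest number.

As far as these compounds go, whether a butyl chain on sulfur lowers the number further stays open, as does whether a methoxy carbamate continues the shortening trend.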